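This account rests on a few compounds, and the source may have more. Where it says the series, first, only, none or still open, it means among the compounds named here.

Compound 1, `CCn1c(C(=O)NCC(=O)OC)ccc1C(CC)(CC)c1ccc(OCS(=O)(=O)c2ccccc2)c(C)c1`, in a functional assay on PC-3 cells (Homo sapiens) for antiproliferative activity, read by MTT assay, with a stated time of 24 h (on this read-out higher numbers stand for weaker inhibition and lower numbers for stronger inhibition), gives only the limit > 50000 nM.
Compound 2, `CCn1c(C(=O)NCCO)ccc1C(CC)(CC)c1ccc(OCS(=O)(=O)c2ccccc2)c(C)c1`, in this assay gives 17700 nM.
Compound 3, `CCn1c(C(=O)NC(C)(C)CO)ccc1C(CC)(CC)c1ccc(OCS(=O)(=O)c2ccccc2)c(C)c1`, in this assay gives 9850 nM.

Among the two numbers shown, compound 3 has the lower one, but its separation from compound 2, a 1.8-fold lower number from compound 2 to compound 3 (0.25 log units; within the scatter), lies within the scatter, so the two cannot be ordered. Compound 1 is known only by its limit, (the limit of > 50000 nM in this assay, at which 1 of the 3 values shown sits).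

Compound 4, `CCn1c(C(=O)NC2(C(=O)O)CC2)ccc1C(CC)(CC)c1ccc(OCS(=O)(=O)c2ccccc2)c(C)c1`, differs from compound 3 in one place: 1-carboxycyclopropyl in place of 1-(hydroxymethyl)-1-methylethyl on an amide-type nitrogen. Within the data shown here, two measured steps bear on this. In an at least 5.0-fold lower number from compound 1 to compound 3 (0.70 log units; beyond the scatter) and in an at least 2.8-fold lower number from compound 1 to compound 2 (0.45 log units; beyond the scatter), the hydroxymethyl-bearing groups accompanied the lower numbers, while the methoxycarbonyl-bearing group sat at the limit. Among the measured compounds shown here, compound 4 gives up the hydroxymethyl and takes on a carboxy group on a three-membered ring, which has no direct precedent here. A modest move back toward higher numbers is therefore expected for compound 4, as a 1.8-fold higher number from compound 3 to compound 4 (0.26 log units; within the scatter). The estimate for compound 4 in this assay is 18000 nM, with a range from 6000 nM to 50000 nM.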

Compound 4, half-maximal inhibitory concentration: 26300 nM
The estimate for compound 4 lay 1.5-fold (0.16 log units) below the measured number, and the stated range covers the measured number.
By their numbers in this assay, from the lowest: compounds 3, 2 and 4 (each within the scatter of the next, the first and the last beyond it). At a limit, above all of these: compound 1.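

In this assay, 1-carboxycyclopropyl in place of 1-(hydroxymethyl)-1-methylethyl on the amide-type nitrogen gives a 2.7-fold higher number from compound 3 to compound 4 (0.43 log units; beyond the scatter), so at this place a group without the hydroxymethyl can lie beyond the scatter from the best-placed number shown. Against the 2-hydroxyethyl group, the same entering group gives only a 1.5-fold higher number from compound 2 to compound 4 (0.17 log units; within the scatter), which leaves those two compounds unordered and makes the separation a matter of the two ends of the series alone. The step of an at least 1.9-fold lower number from compound 1 to compound 4 (0.27 log units; that floor lies within the scatter) has a floor within the scatter, so it does not separate the pair, one of which is held at a limit: the limit of > 50000 nM in this assay, at which 1 of the 4 values shown sits.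

The three-membered ring and the carboxy group enter together, so the compounds shown do not tell which of the two goes with the higher number. From the compounds shown here alone, how a 1-(hydroxymethyl)cyclopropyl group, a carboxylic acid on an open chain or an amine would read at this place remains open.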